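Lengthening the ester chain: from compound 3 to compound 4

A few compounds are considered here, and "the series" means these few. Any claim that something is new, unique, unknown or untested is made for them only; others in the source may bear on it.

Measured so far in an ADME assay on AGS cells (Homo sapiens) for cytotoxicity, read by neutral red uptake, with a stated time of 24 h; on this read-out lower numbers stand for stronger inhibition and higher numbers for weaker inhibition:
- compound 1 `CC(C)c1cc2c3c(c1OC(=O)CCl)OC(=O)[C@@]31CCCC(C)(C)[C@@H]1CC2` gives 103000 nM
- compound 2 `CCCC(=O)Oc1c(C(C)C)cc2c3c1OC(=O)[C@@]31CCCC(C)(C)[C@@H]1CC2` gives 99500 nM
- compound 3 `CCCCCCCCCCCC(=O)Oc1c(C(C)C)cc2c3c1OC(=O)[C@@]31CCCC(C)(C)[C@@H]1CC2` gives 413000 nM

Compound 3 (413000 nM) stands highest of the three, and its gaps to both others lie beyond the scatter. Compound 4 `CCCCCCCC/C=C/CCCCCCCC(=O)Oc1c(C(C)C)cc2c3c1OC(=O)[C@@]31CCCC(C)(C)[C@@H]1CC2` has not yet been measured in this assay and shares the core of compound 3. The structural change is a group of 10 heavy atoms (10 carbon; no ring) in place of a group of 4 heavy atoms (4 carbon; no ring), on a saturated chain carbon, seven bonds along the chain from a carbonyl carbon and the entering group holds 1 double bond outside aromatic rings.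

Among the compounds with values here, two measured steps bear most directly on this change, since each ends at the decyl-bearing chain of compound 3. These are a 4.2-fold higher number from compound 2 to compound 3 (0.62 log units; beyond the scatter) and a 4.0-fold higher number from compound 1 to compound 3 (0.60 log units; beyond the scatter) and both are modest and upward. The third, a 1.0-fold lower number from compound 1 to compound 2 (0.02 log units; within the scatter), stays within the scatter, so the two shorter esters show no separation. Within the data shown here, no measured compound carries a double bond in its chain, and the data offer no direct precedent for that feature.

A further upward step is therefore expected, though smaller than those two and possibly within the scatter. The expected step is a 1.5-fold higher number from compound 3 to compound 4 (0.16 log units; within the scatter) in this assay as estimated here. For compound 4 the estimated value is 600000 nM with an expected range from 250000 nM to 1400000 nM as its span.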

Compound 4, half-maximal inhibitory concentration: 822000 nM
For compound 4 the middle estimate is 1.4-fold (0.14 log units) below the measured one; the measured number falls inside the stated range.
By their numbers in this assay, from the lowest: compounds 2 and 1 (each within the scatter of the next); then compounds 3 and 4 (each within the scatter of the next).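

Working notes on the ester chain: in this assay the change at this position, a 2.0-fold higher number from compound 3 to compound 4 (0.30 log units; within the scatter), leaves compound 3 and compound 4 unseparated. The earlier series showed a separation when the chain was extended, with a 4.2-fold higher number from compound 2 to compound 3 (0.62 log units; beyond the scatter), whereas placing a group of 10 heavy atoms with 1 double bond outside aromatic rings in place of butyl, on a saturated chain carbon seven bonds along the chain from a carbonyl carbon, gives no step beyond the scatter. The available data hold no measurement that accounts for this result.

The compounds shown leave open how chain length and the double bond each contribute, as the two enter together in compound 4, and a fully saturated chain of the same length would be needed to tell them apart. Also open is how this read-out responds to an ester chain carrying an amine or a carboxylic acid, as every chain shown holds only carbon apart from the chloro group of compound 1.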